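Cyclohexyl in Place of Iodine: What to Expect

This account rests on a few compounds, and the source may have more. Where it says the series, first, only, none or still open, it means among the compounds named here.

Compound 1 `O=C(/C=C/c1ccc([N+](=O)[O-])o1)c1ccc(Br)cc1` gives 2700 nM in a functional assay on C6 cells (Rattus norvegicus) for inhibition, read by sulforhodamine B assay, with a stated time of 72 h; a lower number here means that less compound is needed, a higher number that more compound is needed for the effect.
Compound 2 `O=C(/C=C/c1ccc([N+](=O)[O-])o1)c1ccc(I)cc1` gives 2100 nM in this assay.
Compound 3 `O=C(/C=C/c1ccc([N+](=O)[O-])o1)c1ccc(-n2ccnc2)cc1` gives 3500 nM in this assay.

Compound 2 has the smallest of the three numbers, yet the spread is slight: a 1.3-fold lower number from compound 1 to compound 2 (0.11 log units; within the scatter) and a 1.7-fold higher number from compound 2 to compound 3 (0.22 log units; within the scatter) both lie within the scatter, as does a 1.3-fold higher number from compound 1 to compound 3 (0.11 log units; within the scatter). Compound 4 `O=C(/C=C/c1ccc([N+](=O)[O-])o1)c1ccc(C2CCCCC2)cc1` differs from compound 2 in one place: cyclohexyl in place of iodo on an aromatic carbon. Among the measured compounds shown here, no measured step exchanges a halogen for a ring of carbon only, so the only guides are the three exchanges at this same aromatic carbon, none of which moved the number beyond the scatter. The step of a 1.2-fold higher number from compound 2 to compound 4 (0.08 log units; within the scatter) is therefore expected to stay within the scatter as well. Compound 4 is estimated at 2500 nM, with a likely range from 1000 nM to 6000 nM.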

Compound 4, half-maximal effective concentration: 5100 nM
Beside the measured number, compound 4's estimate is 2.0-fold (0.31 log units) below it; the range from low to high includes it.
By their numbers in this assay, from the lowest: compounds 2, 1, 3 and 4 (each within the scatter of the next, the first and the last beyond it).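

Within this assay the change to cyclohexyl on this aromatic carbon gives the only step so far beyond the scatter, a 2.4-fold higher number from compound 2 to compound 4 (0.39 log units; beyond the scatter), although that step is modest. Against the other two groups, cyclohexyl stays within the scatter, with a 1.9-fold higher number from compound 1 to compound 4 (0.28 log units; within the scatter) and a 1.5-fold higher number from compound 3 to compound 4 (0.16 log units; within the scatter), so only the comparison with iodo sets it apart. Nothing available gives a reason for this step. Still open, from the compounds shown here alone, is how an amine, a carboxylic acid or a longer carbon chain on this same aromatic carbon would compare with these four groups.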